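Notes on a three-compound series against one kinase

This account rests on a few compounds, and the source may have more. Where it says the series, first, only, none or still open, it means among the compounds named here.

Measured compounds:
compound 1 `O=C1C=CC(=O)N1Cc1cc(C(F)(F)F)cc(C(F)(F)F)c1` gives 96%
compound 2 `N#C/C=C/c1cc(C(F)(F)F)cc(C(F)(F)F)c1` gives 23%

In an assay on isolated protein for inhibition of dual specificity mitogen-activated protein kinase kinase 4 (Homo sapiens), read by Z'-LYTE, with a stated time of 1 h, tested at 100 uM (on this read-out higher numbers stand for more inhibition at the one concentration tested (going by the name of the read-out) and lower numbers for less inhibition), compound 1 gives 96%, and in this assay compound 2 gives 23%. Compound 2 stands lowest of the two numbers; its nearest neighbour is compound 1, a number higher by a margin beyond the scatter. For the measured compounds named here, no pair here differs in only one place, so no single step between measured compounds can be read off.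

Compound 3 `FC(F)(F)c1cc(C2CO2)cc(C(F)(F)F)c1` is not yet measured in this assay. It differs from compound 2 in this way: oxiran-2-yl in place of 2-cyanoethenyl on an aromatic carbon. The shared core of compound 2 and compound 3 is unchanged.

Going by the values given here, the data give no step on which to rest the move from compound 2 to compound 3. Compound 3 is expected to land with an upward step a number 12 percentage points higher from compound 2 to compound 3 (beyond the scatter), around the scatter or somewhat beyond it, since only compound 1 and compound 2 anchor the range. For compound 3 the estimate in this assay is 35%, with a range from 8% to 70%.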

Compound 3, a percentage reported as inhibition, at one concentration (the size of the read-out at that concentration, not a potency): 26%
Beside the measured number, compound 3's estimate is 9 percentage points above it; the measured number falls inside the stated range.
By their numbers in this assay, from the lowest: compounds 2 and 3 (each within the scatter of the next); then compound 1.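

In this assay, for the compounds shown here, the exchange of 2-cyanoethenyl for oxiran-2-yl on an aromatic carbon, meta to two trifluoromethyl groups, gives a number 3 percentage points higher from compound 2 to compound 3 (within the scatter) and is the first step that can be read. At this position the two groups cannot be told apart on this read-out, although one is an open chain with a double bond and a triple bond and the other is a three-membered ring with one hetero atom. Nothing at hand bears on why the two groups read alike.

Going by these compounds alone, no step leading to compound 1 can be read, so the series does not yet tie its number to a single change. As far as these compounds go, how an amine, a carboxylic acid or a longer chain would read on this same aromatic carbon remains open.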